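Swapping a dichlorophenoxy group for a fluorophenyl sulfide

The source may report more compounds than this note shows. Statements on the series, on what has been measured and on what is new or still open speak of the compounds shown alone.

Three compounds built on a shared core have been examined in a functional assay on OVCAR-8 cells (Homo sapiens) for inhibition, read by sulforhodamine B assay, with a stated time of 48 h; on this read-out higher numbers stand for weaker inhibition of growth and lower numbers for stronger inhibition of growth. Compound 1 `Nc1cc(N)c2nc(-c3ccccc3)c(Oc3ccc(Cl)c(Cl)c3)nc2c1` gives 89100 nM in this assay, the highest number of the three, so it is the weakest inhibitor of growth among them. Compound 2 `CCOC(=O)[C@H](CCC(=O)O)NC(=O)c1ccc(Sc2nc3cc(N)cc(N)c3nc2-c2ccccc2)cc1` gives 39800 nM in this assay, and compound 3 `COc1cc(CNc2nc3cc(N)cc(N)c3nc2-c2ccccc2)cc(OC)c1OC` gives 14800 nM in this assay; both of these gaps from compound 1 lie beyond the usual scatter.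

The next compound, compound 4 `Nc1cc(N)c2nc(-c3ccccc3)c(Sc3ccc(F)cc3)nc2c1`, has not yet been measured. It differs from compound 1 in one place: (4-fluorophenyl)sulfanyl in place of 3,4-dichlorophenoxy on an aromatic carbon. No direct comparison of this kind exists among the measured compounds, so the expectation rests only on the general range the three measured compounds occupy. Because compound 2, which also carries a sulfur-linked aryl group on the core, gives 39800 nM, compound 4 is expected to land at a somewhat lower number than compound 1, with a step of a 1.8-fold lower number from compound 1 to compound 4 (0.25 log units; within the scatter) expected. The estimate for compound 4 in this assay is 50000 nM, with a likely range from 15000 nM to 150000 nM.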

Compound 4, concentration for total growth inhibition: 34700 nM
Beside the measured number, compound 4's estimate is 1.4-fold (0.16 log units) above it; the measured number falls inside the stated range.
By their numbers in this assay, from the lowest: compound 3; then compounds 4 and 2 (each within the scatter of the next); then compound 1.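

In this assay, putting (4-fluorophenyl)sulfanyl in place of 3,4-dichlorophenoxy gives a 2.6-fold lower number from compound 1 to compound 4 (0.41 log units; beyond the scatter), which means stronger inhibition of growth. Among these compounds, this is the first direct one-place comparison, and it shows that the group on this aromatic carbon, next to the ring nitrogen, can shift the read-out beyond the scatter even when the incoming group also carries a six-membered aromatic ring of carbon only. Nothing available here explains why the number falls.

The swap changes both the linking atom and the halogens on the ring, so the compounds shown cannot assign the step to either change. A 4-fluorophenoxy or 3,4-dichlorophenylsulfanyl group at this position would separate the two, while an amine or a carboxylic acid on the aryl ring would test other kinds of group there.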